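The source may hold more compounds than are shown below. What is called first, only, known or untested is meant among the compounds shown, and "the series" means these compounds.

Measured so far:
compound 1 `Cc1cc(O)c(C(=O)/C=C/c2ccccc2)c(-c2ccc(Cl)cc2)c1C(=O)/C=C/c1ccccc1`, "not active" (no number reported)
compound 2 `Cc1cc(O)c(C(=O)/C=C/c2ccc(F)cc2)c(-c2ccc(OCc3ccccc3)cc2)c1C(=O)/C=C/c1ccc(F)cc1`, 25000 nM

In a functional assay on HeLa cells (Homo sapiens) for cytotoxicity, read by MTT assay, with a stated time of 24 h (a higher number here means a weaker inhibitor, a lower number a stronger inhibitor), compound 1 is reported as "not active" (no number reported), so no number marks where it stands; compound 2 gives 25000 nM. Compound 3 `Cc1cc(O)c(C(=O)/C=C/c2ccccc2)c(-c2ccc(OCc3ccccc3)cc2)c1C(=O)/C=C/c1ccccc1` differs from compound 1 by benzyloxy in place of chloro on an aromatic carbon, placed on an aromatic carbon para to a large group. Within the data shown here, no measured pair shows this change, so its size in this assay is unknown. Compound 2 carries the same benzyloxy group and reaches a number, so compound 3 is expected to yield a weak but measurable number, estimated at 30000 nM with a range from 10000 nM to 100000 nM.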

Compound 3, half-maximal inhibitory concentration: "not active" (no number reported)
Compound 3: no number reported, so the estimate cannot be set against anything.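

In this assay compound 3, like compound 1, gives no number, so no step can be read between them. No supporting evidence bears on this result. As far as these compounds go, what replacing chloro with benzyloxy does to potency stays open.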